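The compounds below may be only part of what the source reports. "The series", "measured", "known", "first", "only" and "open" are said of these compounds alone.

In an ADME assay on L02 cells (Homo sapiens) for cytotoxicity, read by MTT assay, with a stated time of 48 h (on this read-out lower numbers stand for stronger inhibition and higher numbers for weaker inhibition), compound 1 `CCN(CC)CCNC(=O)c1ccc(C(CC)(CC)c2ccc(OCC(O)C(C)(C)C)c(C)c2)n1CC` gives 2500 nM, the lowest of the three numbers in hand. Compound 2 `CCn1c(C(=O)N(C)CCC#N)ccc1C(CC)(CC)c1ccc(OCC(O)C(C)(C)C)c(C)c1` gives 14900 nM and compound 3 `CCn1c(C(=O)N(C)CC(=O)O)ccc1C(CC)(CC)c1ccc(OCC(=O)C(C)(C)C)c(C)c1` gives 8700 nM. Compound 4 `CCn1c(C(=O)N(C)CC(=O)O)ccc1C(CC)(CC)c1ccc(OCC(O)C(C)(C)C)c(C)c1` is not yet measured; it differs from compound 1 in one place: (carboxymethyl)(methyl)amino in place of (2-(diethylamino)ethyl)amino on a carbonyl carbon. Going by the values given here, the one measured step that bears on this change is a 6.0-fold higher number from compound 1 to compound 2 (0.78 log units; beyond the scatter), which also exchanges the amine substituent on that carbonyl carbon. Compound 3 carries the same (carboxymethyl)(methyl)amino group as compound 4, though its value cannot be tied to compound 1 by a single step. The step for compound 4 is therefore expected to be a 3.2-fold higher number from compound 1 to compound 4 (0.51 log units; beyond the scatter), a modest rise. Compound 4 is estimated at 8000 nM, with a range from 3500 nM to 18000 nM.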

Compound 4, half-maximal inhibitory concentration: 32600 nM
Estimate against measurement, compound 4: 4.1-fold (0.61 log units) below; the measured number lies above the stated range.
By their numbers in this assay, from the lowest: compound 1; then compounds 3 and 2 (each within the scatter of the next); then compound 4.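

In this assay, (carboxymethyl)(methyl)amino on the carbonyl carbon gives a 13-fold higher number from compound 1 to compound 4 (1.12 log units; beyond the scatter) and so moves the number further than any step seen before. Carboxy in place of cyanomethyl on the saturated chain carbon bound to the amide-type nitrogen gives a 2.2-fold higher number from compound 2 to compound 4 (0.34 log units; beyond the scatter). The number also responds away from the amide, since 1-hydroxy-2,2-dimethylpropyl in place of (tert-butyl)carbonyl gives a 3.7-fold higher number from compound 3 to compound 4 (0.57 log units; beyond the scatter). Nothing at hand explains any of these shifts. Going by these compounds, whether a dimethylamino group or a longer carboxylic acid chain on that carbonyl carbon would stay nearer compound 1 or compound 4 remains open.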